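The source may hold more compounds than are shown below. What is called first, only, known or untested is meant among the compounds shown, and "the series" means these compounds.

Measured in an ADME assay on blood (Canis lupus familiaris, strain Beagle) for protein binding, read by LC-MS, using equilibrium dialysis; on this read-out lower numbers stand for a smaller free fraction and higher numbers for a larger free fraction:
- Compound 1 `CNC(=O)c1cc(C(=O)N[C@H]2CC[C@H](O)CC2)c([C@@H](C)c2cccc(Cl)c2)o1`: 0.1
- Compound 2 `CNC(=O)c1cc(C(=O)N[C@H]2CC[C@H](O)CC2)n([C@@H](C)c2ccccc2)n1`: 0.51
- Compound 3 `CNC(=O)c1cc(C(=O)N[C@H]2[C@@H]3COC[C@@H]32)c([C@@H](C)c2ccccc2)o1`: 0.16

Compound 2 stands highest of the three, beyond the scatter from both compound 3 and compound 1. Compound 4 `CNC(=O)c1cc(C(=O)N[C@H]2CC[C@H](OC)CC2)n([C@@H](C)c2ccccc2)n1` turns its 4-hydroxycyclohexyl into 4-methoxycyclohexyl: methyl in place of hydrogen on an oxygen on a saturated carbon. Going by the values given here, no measured pair differs in one place only, so this step has no direct precedent. With compound 2 at 0.51, the top of the range so far, a modest fall in this assay is expected rather than a rise. The expected step of a 1.4-fold lower number from compound 2 to compound 4 (0.15 log units; within the scatter) is estimated to stay within the scatter. For compound 4 the estimated value is 0.36, with an expected range of 0.2 to 0.55.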

Compound 4, unbound fraction: 0.26
Compound 4: middle estimate off by 1.4-fold (0.14 log units), on the high side; low and high end bracket the measured number.
By their numbers in this assay, from the lowest: compounds 1, 3, 4 and 2 (each within the scatter of the next, the first and the last beyond it).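

In this assay, the series now has its first step in one place, a 2.0-fold lower number from compound 2 to compound 4 (0.29 log units; within the scatter), and it reads on the 4-hydroxycyclohexyl group. On this single pair, methyl in place of hydrogen on the oxygen cannot be told from repeat scatter, so this change gives no measurable shift at this position. No available measurement bears on what lies behind this step.

On these data alone, it remains open whether an ethoxy group or an amine in place of the hydroxy would move the free fraction beyond the scatter. As far as these compounds go, it is also open whether the same methyl change reads alike on the core of compound 1.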